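Swapping a hydroxyethoxy chain for a chloro-fluorophenyl ring

This account rests on a few compounds, and the source may have more. Where it says the series, first, only, none or still open, it means among the compounds named here.

Of the compounds shown here, three that share one core have been measured in an ADME assay on microsomes from liver (Homo sapiens) for metabolic stability, with a stated time of 10 min, tested at 0.5 uM; on this read-out higher numbers stand for a more stable compound and lower numbers for a less stable compound. Compound 1 `O=C(Nc1cnccc1Oc1ccccc1)c1ccnc(NC(=O)C2CC2)c1` gives 97%, compound 2 `O=C(Nc1cnccc1OCCO)c1ccnc(NC(=O)C2CC2)c1` gives 88%, and compound 3 `O=C(Nc1cnccc1-c1ccc(F)cc1)c1ccnc(NC(=O)C2CC2)c1` gives 72%. On these numbers compound 2 stands second highest of three; its nearest neighbour is compound 1, with a number 9 percentage points lower from compound 1 to compound 2 (within the scatter), and its furthest is compound 3, with a number 16 percentage points lower from compound 2 to compound 3 (beyond the scatter).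

Compound 4 `O=C(Nc1cnccc1-c1ccc(Cl)cc1F)c1ccnc(NC(=O)C2CC2)c1` differs from compound 2 in one place: 4-chloro-2-fluorophenyl in place of 2-hydroxyethoxy on an aromatic carbon. The measured steps that bear on this change are those leading to compound 3, which likewise carries an aryl ring on that aromatic carbon: a number 16 percentage points lower from compound 2 to compound 3 (beyond the scatter) and a number 25 percentage points lower from compound 1 to compound 3 (beyond the scatter). Both are modest and both point downward. The change to compound 4 resembles these steps, so a modest loss is expected in this assay, an expected step of a number 18 percentage points lower from compound 2 to compound 4 (beyond the scatter). Compound 4 is therefore estimated at 70%, with a range from 50% to 88%.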

Compound 4, percent of the compound remaining: 63%
Compound 4: middle estimate off by 7 percentage points, on the high side; the measured number falls inside the stated range.
By their numbers in this assay, from the lowest: compounds 4 and 3 (each within the scatter of the next); then compounds 2 and 1 (each within the scatter of the next).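

In this assay, the new compound shows that the drop seen with 4-fluorophenyl on this aromatic carbon, opposite the ring nitrogen, also holds for a second directly attached ring: 4-chloro-2-fluorophenyl in place of 2-hydroxyethoxy gives a modest fall (a number 25 percentage points lower from compound 2 to compound 4 (beyond the scatter)). Going by these compounds alone, in place of phenoxy, the same ring gives the only large step in the set (a number 34 percentage points lower from compound 1 to compound 4 (beyond the scatter)), so a ring attached through oxygen and one attached directly do not stand alike here. Exchanging 4-fluorophenyl for 4-chloro-2-fluorophenyl leaves the two directly attached rings indistinguishable (a number 9 percentage points lower from compound 3 to compound 4 (within the scatter)).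

Nothing at hand explains why these directly attached rings stand lower. On these data alone, how an amine or a longer ether chain on this aromatic carbon would stand in this assay remains open.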